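The source may hold more compounds than are shown below. What is called first, only, known or untested is meant among the compounds shown, and "the series" means these compounds.

Working notes on the series. Three compounds with a shared core carrying a methylpyrrolidinylmethoxy group have been measured in an assay on membranes from brain for displacement of a labelled ligand from Neuronal acetylcholine receptor; alpha4/beta2 (Rattus norvegicus); a lower number here means a stronger inhibitor, a higher number a weaker inhibitor. Compound 1 `Cc1ncccc1OC[C@@H]1CCCN1C` gives 22.9 nM. Compound 2 `Cc1ccncc1OC[C@@H]1CCCN1C` gives 4.12 nM. Compound 3 `CCc1cncc(OC[C@@H]2CCCN2C)c1` gives 0.32 nM, the lowest of the three numbers; compound 2 stands nearest to it and compound 1 furthest, and both gaps lie beyond the scatter, so compound 3 is the strongest binder among the three measured in this assay.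

The next compound, compound 4 `CC(=O)c1cncc(OC[C@@H]2CCCN2C)c1`, differs from compound 3 in one place: acetyl in place of ethyl on an aromatic carbon. Among the compounds with values here, no measured pair shows this change, and nothing measured here tells how an acetyl on that aromatic carbon compares with an ethyl. Within the data shown here, the only basis is that compound 3 itself already gives 0.32 nM in this assay, so there is more room upward than downward.

The step from compound 3 to compound 4 is expected to be modest and towards a higher number, as a 4.7-fold higher number from compound 3 to compound 4 (0.67 log units; beyond the scatter), a step that may or may not clear the scatter. On that basis compound 4 is estimated at 1.5 nM in this assay, with a range from 0.3 nM to 8 nM.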

Compound 4, inhibition constant: 1.19 nM
Compound 4: the middle estimate sits 1.3-fold (0.10 log units) above what was measured; measured number inside the range.
By their numbers in this assay, from the lowest: compound 3; then compound 4; then compound 2; then compound 1.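

Acetyl in place of ethyl on this aromatic carbon, two atoms from the ring nitrogen, gives a 3.7-fold higher number from compound 3 to compound 4 (0.57 log units; beyond the scatter) in this assay. Within the data shown here, this is the first reading of a change at this position, and it shows that a group with a carbonyl can stand there at a cost that remains modest, with the lower number still held by ethyl. This single pair cannot separate the effect of the carbonyl oxygen, with its hydrogen-bond acceptor, from that of the extra heavy atom, and nothing available here accounts for the step.

Open at this same aromatic carbon is where an amine, a carboxylic acid, a longer chain such as propyl, or a hydroxyethyl group, which carries oxygen without a carbonyl, would fall relative to ethyl and acetyl. Also open, going by these compounds, is whether acetyl in place of the methyl of compound 1 or compound 2 would give a step of similar size and direction, or whether this step holds only at the position shared by compound 3 and compound 4.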